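This account rests on a few compounds, and the source may have more. Where it says the series, first, only, none or still open, it means among the compounds named here.

Of the compounds shown here, three have so far been measured in a functional assay on A549 cells (Homo sapiens) for cytotoxicity, read by MTT assay, with a stated time of 72 h; a lower number here means a stronger inhibitor, a higher number a weaker inhibitor. Compound 1 `CCN(CC)Cc1ccc2nc(NC(=O)N/N=C3\C(=O)Nc4ccc(F)cc43)sc2c1` gives 2010 nM, compound 3 `CCN(CC)Cc1ccc2nc(NC(=O)N/N=C/c3c[nH]c4ccccc34)sc2c1` gives 3300 nM, and compound 2 `CC1CCN(Cc2ccc3nc(NC(=O)N/N=C/c4cn(Cc5cccc(Cl)c5)c5ccccc45)sc3c2)CC1` gives 2810 nM. On the number line compound 2 sits between the other two, but its distance from compound 3 and its distance from compound 1 both lie within the usual scatter of repeated measurements, so the three numbers cannot be told apart in this assay.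

Compound 4 `Cc1ccc(Cn2cc(/C=N/NC(=O)Nc3nc4ccc(CN5CCC(C)CC5)cc4s3)c3ccccc32)cc1` has not yet been measured. It differs from compound 2 in one place: 4-methylphenyl in place of 3-chlorophenyl on a saturated chain carbon bound to an aromatic nitrogen. For the measured compounds named here, no pair of measured compounds shows the effect of a change of this kind, so the numbers at hand point to no direction for it. Since the closest measured compound 2 gives 2810 nM, compound 4 is expected to give about 3000 nM in this assay. The expected step of a 1.1-fold higher number from compound 2 to compound 4 (0.03 log units; within the scatter) is none beyond the scatter. The value of compound 4 is estimated to fall between 1500 nM and 6000 nM.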

Compound 4, half-maximal inhibitory concentration: 2180 nM
Estimate against measurement, compound 4: 1.4-fold (0.14 log units) above; low and high end bracket the measured number.
By their numbers in this assay, from the lowest: compounds 1, 4, 2 and 3 (each within the scatter of the next).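

For the compounds shown here, this is the first step that can be read at this position: in this assay, 4-methylphenyl in place of 3-chlorophenyl on a saturated chain carbon bound to an aromatic nitrogen gives a 1.3-fold lower number from compound 2 to compound 4 (0.11 log units; within the scatter). With the same count of heavy atoms on both sides, the two compounds cannot be told apart in this assay, so this one exchange of a chlorine-bearing ring for a methyl-bearing ring leaves the number unresolved from where it stood. Nothing measured here speaks to why the two compounds match.

From the compounds shown here alone, the group and its place on the ring change together in this step, so whether 3-methylphenyl or 4-chlorophenyl would match as well stays open. Also open, going by these compounds, is whether an amine or a carboxylic acid on this ring, or a longer chain in place of the benzyl group, would move the number beyond the scatter.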